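The source may report more compounds than this note shows. Statements on the series, on what has been measured and on what is new or still open speak of the compounds shown alone.

Measured compounds:
compound 1 `CC1=CC[C@@H]([C@@](C)(O)CCCC(C)(C)NC(=S)N/N=C\c2ccc(O)cc2)CC1`: 8390 nM in a functional assay on NCI/ADR cells (Homo sapiens) for cytotoxicity, read by sulforhodamine B assay; a higher number here means a weaker inhibitor of growth, a lower number a stronger inhibitor of growth
compound 2 `CC1=CC[C@@H]([C@@](C)(O)CCCC(C)(C)NC(=S)N/N=C\c2ccccc2[N+](=O)[O-])CC1`: 20400 nM in this assay
compound 3 `CC1=CC[C@@H]([C@@](C)(O)CCCC(C)(C)NC(=S)N/N=C\c2ccc([N+](=O)[O-])cc2)CC1`: 12800 nM in this assay

Compound 3 gives the second highest of the three numbers, and both of its neighbours lie within the scatter of it: a 1.5-fold higher number from compound 1 to compound 3 (0.18 log units; within the scatter) and a 1.6-fold lower number from compound 2 to compound 3 (0.20 log units; within the scatter). Compound 4 `CC1=CC[C@@H]([C@@](C)(O)CCCC(C)(C)NC(=S)N/N=C\c2ccccc2Cl)CC1` differs from compound 3 in one place: 2-chlorophenyl in place of 4-nitrophenyl on a carbon with a double bond to nitrogen. Going by the values given here, no measured compound carries a chlorine, so the only steps that bear on this change concern the aryl group itself: the shift a 1.6-fold lower number from compound 2 to compound 3 (0.20 log units; within the scatter) was within the scatter, while a 2.4-fold higher number from compound 1 to compound 2 (0.39 log units; beyond the scatter) was modest. For compound 4 in this assay a step of about a 1.2-fold higher number from compound 3 to compound 4 (0.07 log units; within the scatter) is therefore expected, not clearly beyond the scatter. Compound 4 is estimated at 15000 nM, with a range from 6000 nM to 40000 nM.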

Compound 4, concentration for 50% growth inhibition: > 100000 nM
Compound 4: a limit, no number (the forecaster's own chance of this, stated with the estimate: 10%); middle value at least 6.6-fold (0.82 log units) from the limit.
By their numbers in this assay, from the lowest: compounds 1, 3 and 2 (each within the scatter of the next, the first and the last beyond it). At a limit, above all of these: compound 4.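

In this assay compound 4 stands at a limit of the assay, not at a number: the limit of > 100000 nM in this assay, at which 1 of the 4 values shown sits. The change to 2-chlorophenyl on the carbon with a double bond to nitrogen gives an at least 7.8-fold higher number from compound 3 to compound 4 (0.89 log units; beyond the scatter) and an at least 4.9-fold higher number from compound 2 to compound 4 (0.69 log units; beyond the scatter) and also an at least 11-fold higher number from compound 1 to compound 4 (1.07 log units; beyond the scatter). The aryl group at this place therefore matters more than the smaller steps among compound 1, compound 2 and compound 3 had shown.

The compounds shown leave open whether the chlorine itself or its place on the ring carries this step. From the compounds shown here alone, how a bromine or a methoxy group on that ring would read also remains open.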